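Acetyl in place of trifluoromethyl: working notes on compound 3

A few compounds are considered here, and "the series" means these few. Any claim that something is new, unique, unknown or untested is made for them only; others in the source may bear on it.

In a functional assay (aorta) with Rattus norvegicus as the target (on this read-out higher numbers stand for weaker inhibition and lower numbers for stronger inhibition), compound 1 (`CC1(C)Oc2ccc(C#N)cc2[C@@H](/N=C(\NC#N)Nc2ccccc2)[C@@H]1O`) gives 1400 nM; 1300 nM (2 entries). Going by the values given here, compound 2 (`CC1(C)Oc2ccc(C#N)cc2[C@@H](/N=C(\NC#N)Nc2ccc(C(F)(F)F)cc2)[C@@H]1O`), which carries a trifluoromethyl group, gives 8100 nM, its only single number in this assay, with one further entry lacking a single number. That value is higher than the value for compound 1, which places compound 2 on the weaker side of the pair.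

Compound 3 (`CC(=O)c1ccc(N/C(=N/[C@@H]2c3cc(C#N)ccc3OC(C)(C)[C@H]2O)NC#N)cc1`) has acetyl in place of trifluoromethyl on an aromatic carbon, para to a large group (acetyl in place of trifluoromethyl on an aromatic carbon). Among the compounds with values here, no measured step of this kind is available. A moderate shift toward lower numbers in this assay is expected, an expectation resting on compound 1, which lacks both groups, at 1400 nM; 1300 nM (2 entries). The estimated step of a 2.3-fold lower number from compound 2 to compound 3 (0.36 log units; beyond the scatter) stays modest. For compound 3 the estimated value is 3500 nM, with an expected range of 1200 nM to 10000 nM.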

Compound 3, half-maximal inhibitory concentration: 21000 nM
Compound 3: middle estimate off by 6.0-fold (0.78 log units), on the low side, and the stated range ends below it.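

Putting acetyl in place of trifluoromethyl on an aromatic carbon, para to a large group, gives a 2.6-fold higher number from compound 2 to compound 3 (0.41 log units; beyond the scatter) in this assay, so the hydrogen-bond acceptor that acetyl brings does not come with a lower number here. This position now has a second group on the weaker side of the unsubstituted parent: compound 2 at 8100 nM and compound 3 at 21000 nM both lie above compound 1 at 1400 nM; 1300 nM (2 entries). That comparison rests on a reference that holds up on repetition: the several entries of compound 1 in this assay, 1400 nM; 1300 nM (2 entries)

Going by these compounds, it remains open whether any group at this position gives a number lower than that of compound 1, for example an amine or a single fluorine atom. The compounds shown also cannot tell which feature of acetyl and trifluoromethyl sets the gap between them.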